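The compounds below may be only part of what the source reports. "The series", "measured", "known", "first", "only" and "open" are said of these compounds alone.

Measured so far in a functional assay on the whole organism with Mus musculus as the target (a lower number here means that less compound is needed, a higher number that more compound is needed for the effect), for the series:
Compound 1 `COc1ccc(-c2nc3cccnc3n2CC(=O)N(C)C)cc1` gives 39.5 mg/kg
Compound 2 `CCCN(CCC)C(=O)Cn1c(-c2ccc(Cl)cc2)nc2cccnc21` gives 11 mg/kg

Compound 2 holds the lower of the two numbers, and the gap to compound 1 lies beyond the scatter. Compound 3 `O=C(Cn1c(-c2ccc(Cl)cc2)nc2cccnc21)Nc1cccnc1` puts (pyridin-3-yl)amino in place of dipropylamino on a carbonyl carbon. Among the compounds with values here, no measured pair isolates a change at this place, so the expectation is loose. A higher number than that of compound 2 is expected in this assay, with a modest step beyond the scatter. The estimated step is (a 2.5-fold higher number from compound 2 to compound 3 (0.41 log units; beyond the scatter)). Compound 3 is estimated at 28 mg/kg in a range from 9 mg/kg to 85 mg/kg for now.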

Compound 3, dose for half-maximal effect: 100 mg/kg
Compound 3: the middle estimate sits 3.6-fold (0.55 log units) below what was measured; measured number outside the range, above it.
By their numbers in this assay, from the lowest: compound 2; then compound 1; then compound 3.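

In this assay the group on the carbonyl carbon proves to matter: (pyridin-3-yl)amino in place of dipropylamino gives a 9.1-fold higher number from compound 2 to compound 3 (0.96 log units; beyond the scatter) even though the heavy-atom count stays equal, so that count alone does not set the number. This single step changes the aromatic ring, the ring nitrogen and the amide hydrogen together, and cannot separate them. Nothing on hand accounts for the shift.

Open, as far as these compounds go, is whether phenylamino, which has the ring but no ring nitrogen, follows compound 3. Also open, from the compounds shown here alone, is whether piperidin-1-yl, which has no amide hydrogen, stays close to compound 2.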